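Swapping Cyclopropyl for Methyl on Compound 2

The compounds below may be only part of what the source reports. "The series", "measured", "known", "first", "only" and "open" are said of these compounds alone.

Three compounds carrying the (cyclopropylsulfonyl)carbamoyl group have been measured in an ADME assay for permeability, using PAMPA, at pH 5.5 (a lower number here means that the compound crosses the layer more slowly, a higher number that the compound crosses the layer faster), so far. Compound 1 (`Cn1cc(-c2ccc(C(F)(F)F)cc2)c2cc(F)c(C(=O)NS(=O)(=O)C3CC3)cc21`) gives 1660 nm/s in this read-out, compound 3 (`CC(C)COc1ccc(-c2nn(C)c3cc(C(=O)NS(=O)(=O)C4CC4)c(F)cc23)cn1`) gives 762 nm/s and compound 2 (`CC(C)COc1ncc(-c2cn(C)c3cc(C(=O)NS(=O)(=O)C4CC4)c(F)cc23)cc1Cl`) gives 335 nm/s as the lowest of the three. Within the data shown here, both gaps above compound 2 lie beyond the usual scatter, the one to compound 3 being the nearer and the one to compound 1 the further.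

Compound 4 (`CC(C)COc1ncc(-c2cn(C)c3cc(C(=O)NS(C)(=O)=O)c(F)cc23)cc1Cl`) has not yet been measured. It differs from compound 2 in one place, with methyl in place of cyclopropyl on a sulfonyl sulfur. Among the measured compounds shown here, no two measured compounds differ in one place only, so the data offer no direct precedent for this change. The expectation therefore rests on compound 2 at 335 nm/s as the starting point, and a small downward step in this assay is expected, most likely within the scatter. The estimated change is a 1.4-fold lower number from compound 2 to compound 4 (0.15 log units; within the scatter) on this reasoning. Compound 4 is expected to read about 235 nm/s with an estimated range from 115 nm/s to 440 nm/s once it is measured.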

Compound 4, apparent permeability: 495 nm/s
Compound 4: middle estimate off by 2.1-fold (0.32 log units), on the low side; measured number above the stated range.
By their numbers in this assay, from the lowest: compounds 2, 4 and 3 (each within the scatter of the next, the first and the last beyond it); then compound 1.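

Among these compounds, this is the first pair that differs in one place only, and in this assay it gives a 1.5-fold higher number from compound 2 to compound 4 (0.17 log units; within the scatter). On the core of compound 2, the sulfonyl sulfur whose other neighbour is an amide-type nitrogen therefore carries either cyclopropyl or methyl with no difference that this read-out can resolve, even though the exchange removes the three-membered ring and takes the group from 3 heavy atoms to 1. No measured information on the compounds accounts for how closely these two readings agree.

This single pair says nothing about whether the same exchange would give a comparable step on the cores of compound 1 and compound 3, which carry other groups elsewhere and are represented here only by their cyclopropyl forms. It also leaves open how the sulfonyl sulfur would respond to groups that differ more from these two, such as a longer chain like n-butyl, a phenyl ring or a dimethylamino group, so the range of groups accepted at this position remains undefined.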